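Benzothiazole series: acetylated cysteine ester variant, compound 4

A few compounds are considered here, and "the series" means these few. Any claim that something is new, unique, unknown or untested is made for them only; others in the source may bear on it.

Measured in a functional assay on MCF7 cells (Homo sapiens) for inhibition, read by MTT assay, with a stated time of 3 days; on this read-out higher numbers stand for weaker inhibition and lower numbers for stronger inhibition:
compound 1, `COc1cc(-c2nc3ccccc3s2)ccc1OCC(=O)NNC(=O)CN[C@@H](CS)C(=O)O`, gives 1230 nM
compound 2, `CCOC(=O)CN(C)CC(=O)NNC(=O)COc1ccc(-c2nc3ccccc3s2)cc1OC`, gives 1980 nM
compound 3, `CCOC(=O)[C@@H](NCC(=O)NNC(=O)COc1ccc(-c2nc3ccccc3s2)cc1OC)[C@@H](C)CC`, gives 1950 nM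

Compound 1 has the lowest of the three numbers, but the steps to the others, a 1.6-fold higher number from compound 1 to compound 3 (0.20 log units; within the scatter) and a 1.6-fold higher number from compound 1 to compound 2 (0.21 log units; within the scatter), both lie within the scatter, so the three compounds are not separated.

Compound 4, `CCOC(=O)[C@H](CS)N(CC(=O)NNC(=O)COc1ccc(-c2nc3ccccc3s2)cc1OC)C(C)=O`, differs from compound 1 in one place: acetyl(1-(ethoxycarbonyl)-2-sulfanylethyl)amino in place of (1-carboxy-2-sulfanylethyl)amino on a saturated chain carbon bound to a carbonyl carbon. Both known steps from compound 1 replace the same amino group at that carbon with another amino-acid-derived group, and neither moved this assay beyond the scatter. No step beyond the scatter is therefore expected for compound 4. Compound 4 is estimated at 1600 nM, range 700 nM to 3600 nM, which means an expected step of a 1.3-fold higher number from compound 1 to compound 4 (0.11 log units; within the scatter).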

Compound 4, half-maximal inhibitory concentration: 1890 nM
Compound 4: the middle estimate sits 1.2-fold (0.07 log units) below what was measured; low and high end bracket the measured number.
By their numbers in this assay, from the lowest: compounds 1, 4, 3 and 2 (each within the scatter of the next).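

Swapping (1-carboxy-2-sulfanylethyl)amino for acetyl(1-(ethoxycarbonyl)-2-sulfanylethyl)amino gives a 1.5-fold higher number from compound 1 to compound 4 (0.19 log units; within the scatter) even though the sulfanylethyl chain is kept and both an ethyl ester and an acetyl on the nitrogen are added. The steps of a 1.0-fold lower number from compound 3 to compound 4 (0.01 log units; within the scatter) and a 1.0-fold lower number from compound 2 to compound 4 (0.02 log units; within the scatter) leave compound 4 unseparated from the other two esters as well, so this position has now taken an acetylated amine without a step beyond the scatter. No available evidence bears on this result.

As far as these compounds go, whether a primary amine or a longer alkyl chain with no ester on this saturated chain carbon would move the number beyond the scatter remains open.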